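Swapping the Aromatic Group on the Vinyl Carbon

The compounds below may be only part of what the source reports. "The series", "measured", "known", "first", "only" and "open" are said of these compounds alone.

Compound 2 `Cc1ccc(CS/C(=C/c2ccccc2Br)C(=O)c2ccc(Cl)cc2)cc1` and compound 1 `Cc1ccc(CS/C(=C/c2cc([N+](=O)[O-])ccc2F)C(=O)c2ccc(Cl)cc2)cc1` share one core and differ only in the aromatic group on a double-bonded chain carbon. In a functional assay on DU-145 cells (Homo sapiens) for inhibition, read by trypan blue exclusion, with a stated time of 96 h (on this read-out lower numbers stand for stronger inhibition of growth and higher numbers for weaker inhibition of growth), compound 2 gives 10000 nM, the highest of the two numbers; compound 1 gives 1000 nM. The step of a 10-fold higher number from compound 1 to compound 2 (1.00 log units; beyond the scatter) shows that changing this aromatic group alone can move the read-out well beyond the scatter. Compound 3 `CSc1ccc(/C=C(/SCc2ccc(C)cc2)C(=O)c2ccc(Cl)cc2)cc1` makes a further change at that place: 4-(methylsulfanyl)phenyl in place of 2-bromophenyl on a double-bonded chain carbon bound to a double-bonded chain carbon. Within the data shown here, only that one earlier step bears on it, and it sets no direction, since nothing resembling the new group has been measured. A step of comparable size either way is possible, so a modest shift is expected, a 2.5-fold lower number from compound 2 to compound 3 (0.40 log units; beyond the scatter), with a wide range around it. Compound 3 is estimated to give 4000 nM in this assay, between 800 nM and 20000 nM.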

Compound 3, concentration for 50% growth inhibition: 25000 nM
The estimate for compound 3 lay 6.3-fold (0.80 log units) below the measured number; the measured number lies above the stated range.
By their numbers in this assay, from the lowest: compound 1; then compound 2; then compound 3.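

Among these compounds, the step to 4-(methylsulfanyl)phenyl gives a 2.5-fold higher number from compound 2 to compound 3 (0.40 log units; beyond the scatter), so the sensitivity of this place to the aromatic group is not confined to the single swap seen earlier. Across the full span, the change gives a 25-fold higher number from compound 1 to compound 3 (1.40 log units; beyond the scatter), a large step that makes compound 3 the weakest growth inhibitor of the three and compound 1 the strongest. No measurement here explains why these aromatic groups rank in this order.

The swap from compound 2 to compound 3 removes bromine and adds a methylsulfanyl group at once, so the compounds shown leave open how much each of those two changes contributes. They also leave open how a plain phenyl ring, or a phenyl ring bearing an amine or a carboxylic acid, would behave at this place.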